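Chloro to nitro on the benzyl of the shared core

The source may report more compounds than this note shows. Statements on the series, on what has been measured and on what is new or still open speak of the compounds shown alone.

compound 1 `NC(=O)c1c(NC(=O)c2ccccc2Cl)sc2c1CCNC2` — 28700 nM
compound 2 `NC(=O)c1c(NC(=O)c2ccccc2Cl)sc2c1CCN(Cc1ccc(Cl)cc1)C2` — 18700 nM
compound 3 `NC(=O)c1c(NC(=O)c2ccccc2Cl)sc2c1CCN(Cc1ccc([N+](=O)[O-])cc1)C2` — not yet measured

In a functional assay on MKN-74 cells (Homo sapiens) for antiproliferative activity, with a stated time of 24 h (on this read-out lower numbers stand for stronger inhibition and higher numbers for weaker inhibition), compound 1 gives 28700 nM and compound 2 gives 18700 nM. The step of a 1.5-fold lower number from compound 1 to compound 2 (0.19 log units; within the scatter) leaves the two within the scatter of each other, so compound 2 stands apart from compound 1 by nothing that can be read. Compound 3 differs from compound 2 by nitro in place of chloro on an aromatic carbon. Among the measured compounds shown here, no measured step alters a group on the 4-chlorobenzyl; the only measured step introduced the benzyl itself, so nothing bears directly on this change. Compound 3 is therefore expected to show a 1.1-fold higher number from compound 2 to compound 3 (0.03 log units; within the scatter), nothing beyond the scatter. For compound 3 the estimate in this assay is 20000 nM, ranging from 7000 nM to 55000 nM.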

Compound 3, half-maximal inhibitory concentration: 31500 nM
Compound 3: the middle estimate sits 1.6-fold (0.20 log units) below what was measured, within the range that was stated.
By their numbers in this assay, from the lowest: compounds 2, 1 and 3 (each within the scatter of the next).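

In this assay, this position now carries a second group, and the step of a 1.7-fold higher number from compound 2 to compound 3 (0.23 log units; within the scatter) shows that nitro in place of chloro on this aromatic carbon gives no readable change. The step of a 1.1-fold higher number from compound 1 to compound 3 (0.04 log units; within the scatter) shows that 4-nitrobenzyl, like 4-chlorobenzyl, cannot be told apart from hydrogen on the ring amine nitrogen. No data shown here offer an explanation for these results.

Still open, as far as these compounds go, is whether an amine or a carboxylic acid on this aromatic carbon would give a step beyond the scatter. From the compounds shown here alone, a longer chain in place of the benzyl also remains open.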